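Shrinking the Aryl Group on the Urea

The source may report more compounds than this note shows. Statements on the series, on what has been measured and on what is new or still open speak of the compounds shown alone.

Three measured compounds share one core and differ only in the aryl group on the urea. Compound 1 `COc1cc(Nc2ncnc3c(NC(=O)Nc4cccc(Oc5ccccc5)c4)cccc23)cc(OC)c1` in a functional assay on RT-112 cells (Homo sapiens) for antiproliferative activity, read by MTT assay, with a stated time of 72 h (on this read-out lower numbers stand for stronger inhibition of growth and higher numbers for weaker inhibition of growth), gives 14000 nM. Compound 2 `COc1cc(Nc2ncnc3c(NC(=O)Nc4ccc(Cl)c(C(F)(F)F)c4)cccc23)cc(OC)c1` reaches only a limit of the assay, > 20000 nM. Compound 3 `COc1cc(Nc2ncnc3c(NC(=O)Nc4ccc(C(F)(F)F)cc4[N+](=O)[O-])cccc23)cc(OC)c1` likewise reaches only a limit, > 20000 nM. Compound 2 therefore stands at the limit of > 20000 nM in this assay, at which 2 of the 3 values shown sit, and no number for it is known. Compound 4 `COc1cc(Nc2ncnc3c(NC(=O)Nc4ccc(F)cc4F)cccc23)cc(OC)c1` is not yet measured; it differs from compound 2 by 2,4-difluorophenyl in place of 4-chloro-3-(trifluoromethyl)phenyl on an amide-type nitrogen. Within the data shown here, no step between measured compounds is available, so the expectation rests on compound 1, which gives 14000 nM with another aryl group. The step of an at least 1.3-fold lower number from compound 2 to compound 4 (0.12 log units; that floor lies within the scatter) is expected to be small, at most a modest gain. Compound 4 is estimated at 15000 nM, between 5000 nM and 40000 nM.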

Compound 4, concentration for 50% growth inhibition: 2460 nM
Beside the measured number, compound 4's estimate is 6.1-fold (0.79 log units) above it; measured number below the stated range.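

In this assay, the aryl group on the urea can shift growth inhibition by more than the usual scatter: 2,4-difluorophenyl in place of 4-chloro-3-(trifluoromethyl)phenyl gives an at least 8.1-fold lower number from compound 2 to compound 4 (0.91 log units; beyond the scatter). Among these compounds, this is the first readable step, and it comes with a smaller aryl group. Compound 2 holds a limit, not a number: the limit of > 20000 nM in this assay, at which 2 of the 4 values shown sit.

Going by these compounds, the whole aryl group changes in this one step, so what the chlorine, the trifluoromethyl and the two fluorines each contribute stays open. Plain phenyl or 4-fluorophenyl on the same nitrogen would help separate them.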